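Swapping one saturated oxygen ring for another on the ether

The source may hold more compounds than are shown below. What is called first, only, known or untested is meant among the compounds shown, and "the series" means these compounds.

Compound 1 `CCN(CC)CCCNc1ccc(S(=O)(=O)NC(=O)c2ccc(N3CCN(CC4=C(c5ccc(C(F)(F)F)cc5)CC(C)(C)CC4)CC3)cc2Oc2cnc3[nH]ccc3c2)cc1[N+](=O)[O-]` gives 0.3 nM in an assay on isolated protein for displacement of a labelled ligand from Apoptosis regulator Bcl-2 (Homo sapiens), with a stated time of 15 min; on this read-out lower numbers stand for stronger inhibition and higher numbers for weaker inhibition. Compound 2 `CC1(C)CCC(CN2CCN(c3ccc(C(=O)NS(=O)(=O)c4ccc(NCC5CCOC5)c([N+](=O)[O-])c4)c(Oc4cnc5[nH]ccc5c4)c3)CC2)=C(c2ccc(C(F)(F)F)cc2)C1` gives 4.7 nM and compound 3 `CC1(C)CCC(CN2CCN(c3ccc(C(=O)NS(=O)(=O)c4ccc(OCC5CCCOC5)c([N+](=O)[O-])c4)c(Oc4cnc5[nH]ccc5c4)c3)CC2)=C(c2ccc(C(F)(F)F)cc2)C1` gives 3 nM, so compound 3 has the second highest number of the three. The change to compound 4 `CC(Oc1ccc(S(=O)(=O)NC(=O)c2ccc(N3CCN(CC4=C(c5ccc(C(F)(F)F)cc5)CC(C)(C)CC4)CC3)cc2Oc2cnc3[nH]ccc3c2)cc1[N+](=O)[O-])C1CCOCC1` is 1-(oxan-4-yl)ethyl in place of (oxan-3-yl)methyl on an oxygen on an aromatic ring. The step most like it, a 1.6-fold lower number from compound 2 to compound 3 (0.19 log units; within the scatter), swapped one saturated oxygen ring for another and stayed within the scatter, whereas a 10-fold higher number from compound 1 to compound 3 (1.00 log units; beyond the scatter) removed the whole basic chain. Since only a ring and its link change here, no step beyond the scatter is expected, no change at the digits printed from compound 3 to compound 4 (within the scatter). Compound 4 is therefore estimated at 3 nM, within 1 nM to 9 nM.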

Compound 4, half-maximal inhibitory concentration: 9.2 nM
The estimate for compound 4 lay 3.1-fold (0.49 log units) below the measured number, outside the stated range (above it).
By their numbers in this assay, from the lowest: compound 1; then compounds 3, 2 and 4 (each within the scatter of the next, the first and the last beyond it).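

On the oxygen on the aromatic ring, 1-(oxan-4-yl)ethyl in place of (oxan-3-yl)methyl gives (a 3.1-fold higher number from compound 3 to compound 4 (0.49 log units; beyond the scatter)), so a swap that keeps one six-membered ring with one oxygen can still go beyond the scatter here. Compound 4 stays within the scatter of compound 2 (a 2.0-fold higher number from compound 2 to compound 4 (0.29 log units; within the scatter)), while the step from the chain of compound 1 remains much larger (a 31-fold higher number from compound 1 to compound 4 (1.49 log units; beyond the scatter)). No measurement here accounts for these steps.

From the compounds shown here alone, two things change at once in this swap, so the shares of the added carbon and the moved ring attachment stay open. Also open, going by these compounds, is how a piperidine ring bearing an amine would compare on this oxygen.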